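This account rests on a few compounds, and the source may have more. Where it says the series, first, only, none or still open, it means among the compounds named here.

Of the compounds shown here, two carry numbers so far. Compound 1 `C=C1CC[C@@H]2[C@](C)(CNCc3ccccc3)[C@H](O)CC[C@@]2(C)[C@@H]1/C=C/C1=CCOC1=O` bears an unsubstituted benzyl on the amine nitrogen; in a functional assay on BMMC cells (Mus musculus, strain C57BL/6) for inhibition, with stated times of 5 days and 48 h (on this read-out higher numbers stand for weaker inhibition and lower numbers for stronger inhibition), compound 1 gives 960 nM. Compound 2 `C=C1CC[C@@H]2[C@](C)(CNCc3ccc(OC)cc3)[C@H](O)CC[C@@]2(C)[C@@H]1/C=C/C1=CCOC1=O` differs from it by a methoxy in place of hydrogen on an aromatic carbon; in this assay compound 2 gives 750 nM. Among the compounds with values here, the step of a 1.3-fold lower number from compound 1 to compound 2 (0.11 log units; within the scatter) is the only measured step in the set. On the numbers shown, compound 2 has the lowest number of the two, but its gap to compound 1 lies within the scatter, so no order between them can be claimed.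

Compound 3 `C=C1CC[C@@H]2[C@](C)(CNCc3cccc(OC)c3)[C@H](O)CC[C@@]2(C)[C@@H]1/C=C/C1=CCOC1=O` is the next member. It differs from compound 2 as 3-methoxyphenyl in place of 4-methoxyphenyl on a saturated chain carbon bound to an amine nitrogen. Within the data shown here, no measured step covers a move of the methoxy from one aromatic carbon to another; the only step available, a 1.3-fold lower number from compound 1 to compound 2 (0.11 log units; within the scatter), shows that adding a methoxy at all gave a step within the scatter. The expectation is therefore a step within the scatter, a 1.1-fold higher number from compound 2 to compound 3 (0.05 log units; within the scatter), in no particular direction. Compound 3 is estimated in this assay at 850 nM, with a range from 350 nM to 2000 nM.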

Compound 3, half-maximal inhibitory concentration: 780 nM
The estimate for compound 3 lay 1.1-fold (0.04 log units) above the measured number, within the range that was stated.
By their numbers in this assay, from the lowest: compounds 2, 3 and 1 (each within the scatter of the next).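

In this assay, moving the methoxy gives a 1.0-fold higher number from compound 2 to compound 3 (0.02 log units; within the scatter) and so 3-methoxyphenyl and 4-methoxyphenyl on a saturated chain carbon bound to an amine nitrogen cannot be told apart in this series. Methoxy in place of hydrogen at the second aromatic carbon gives a 1.2-fold lower number from compound 1 to compound 3 (0.09 log units; within the scatter) and so this change, like the one to the 4-methoxybenzyl compound, stays within the scatter; the unsubstituted benzyl and both methoxybenzyl groups therefore form a single group of values with no order among them. No information bears on the reason for this insensitivity to the methoxy or its place.

Going by these compounds, whether a carboxylic acid or a dimethylamino group in place of the methoxy on the aromatic ring would give a step beyond the scatter remains open, as does the effect of a longer chain between the amine nitrogen and that ring. All three compounds shown keep an aromatic ring on that chain, so the outcome of replacing it with a cyclohexyl group or a simple methyl group is also unknown.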